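Swapping Fluoro for Ethoxycarbonyl on the Anilide Ring

The compounds below may be only part of what the source reports. "The series", "measured", "known", "first", "only" and "open" are said of these compounds alone.

Compound 1, `O=C(CSC(=S)N[C@H]1CCOC1=O)Nc1ccc(Br)cc1`: 66500 nM
Compound 2, `Cc1ccc(NC(=O)CSC(=S)N[C@H]2CCOC2=O)cc1`: 33500 nM
Compound 3, `O=C(CSC(=S)N[C@H]1CCOC1=O)Nc1ccc(F)cc1`: 5830 nM

All three compounds share one core and differ only in the group on the aromatic ring of the anilide. In a functional assay on MCF7 cells (Homo sapiens) for cytotoxicity, read by MTT assay, with a stated time of 72 h (a lower number here means a stronger inhibitor, a higher number a weaker inhibitor), compound 3 stands lowest of the three: the step of a 5.7-fold lower number from compound 2 to compound 3 (0.76 log units; beyond the scatter) is beyond the scatter, and the step of an 11-fold lower number from compound 1 to compound 3 (1.06 log units; beyond the scatter) is larger still. The step of a 2.0-fold lower number from compound 1 to compound 2 (0.30 log units; within the scatter) lies within the scatter, so compound 1 and compound 2 cannot be ordered against each other.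

Compound 4, `CCOC(=O)c1ccc(NC(=O)CSC(=S)N[C@H]2CCOC2=O)cc1`, has not yet been measured. It differs from compound 3 in one place: ethoxycarbonyl in place of fluoro on an aromatic carbon.

For the measured compounds named here, no measured step involves an ethoxycarbonyl group, so the bearing of the known steps is indirect. What they do show is that the fluoro group of compound 3 gives a lower number than either the bromo of compound 1 or the methyl of compound 2, and those two steps toward fluoro were the only ones beyond the scatter. Leaving the fluoro group for a group of five heavy atoms is therefore expected to move the number upward, by a step of a 5.1-fold higher number from compound 3 to compound 4 (0.71 log units; beyond the scatter), in the direction of compound 2 and compound 1. The estimate for compound 4 in this assay is 30000 nM, with a range from 8000 nM to 100000 nM.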

Compound 4, half-maximal inhibitory concentration: 60300 nM
Estimate against measurement, compound 4: 2.0-fold (0.30 log units) below; the range from low to high includes it.
By their numbers in this assay, from the lowest: compound 3; then compounds 2, 4 and 1 (each within the scatter of the next).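

In this assay, ethoxycarbonyl on this aromatic carbon, para to a large group, gives up what fluoro had gained, in a large step (a 10-fold higher number from compound 3 to compound 4 (1.01 log units; beyond the scatter)). The new group cannot be told apart from either of the other two: the step from methyl (a 1.8-fold higher number from compound 2 to compound 4 (0.26 log units; within the scatter)) and the step from bromo (a 1.1-fold lower number from compound 1 to compound 4 (0.04 log units; within the scatter)) both lie within the scatter, so three quite different groups now sit on one level and compound 3 alone stands apart as the strongest of the four, which shows that the earlier separation was not a peculiarity of bromo and methyl but holds against a group of five heavy atoms with two hydrogen-bond acceptors as well. No measurement at hand explains why fluoro stands apart from these three groups.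

From the compounds shown here alone, what a chloro group, an amine or a carboxylic acid would give at this carbon remains open, so it cannot be said whether the low number belongs to fluoro alone or to a wider set of groups. Also open, going by these compounds, is whether the same order would hold in any other cell line, since all four values come from this assay alone.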